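Dimethoxyphenyl in place of methylphenyl on the amide

The source may report more compounds than this note shows. Statements on the series, on what has been measured and on what is new or still open speak of the compounds shown alone.

Compound 1 `O=C(O)CCC(=O)OCCCCCCSc1ccc([N+](=O)[O-])c2nonc12`: 740 nM in an ADME assay on HUVEC cells (Homo sapiens) for cytotoxicity, read by MTT assay, with a stated time of 72 h; a higher number here means a weaker inhibitor, a lower number a stronger inhibitor
Compound 2 `O=C(CCC(=O)OCCCCCCSc1ccc([N+](=O)[O-])c2nonc12)Nc1ccccc1F`: 840 nM in this assay
Compound 3 `Cc1ccccc1NC(=O)CCC(=O)OCCCCCCSc1ccc([N+](=O)[O-])c2nonc12`: 1410 nM in this assay

Compound 3 gives the highest of the three numbers, yet its steps to the others are small: a 1.9-fold higher number from compound 1 to compound 3 (0.28 log units; within the scatter) and a 1.7-fold higher number from compound 2 to compound 3 (0.22 log units; within the scatter) both lie within the scatter, so the three compounds cannot be told apart. Compound 4 `COc1ccc(NC(=O)CCC(=O)OCCCCCCSc2ccc([N+](=O)[O-])c3nonc23)cc1OC` carries 3,4-dimethoxyphenyl in place of 2-methylphenyl on an amide-type nitrogen. Among the measured compounds shown here, two measured steps touch the same amide end of the molecule: a 1.1-fold higher number from compound 1 to compound 2 (0.06 log units; within the scatter) and a 1.7-fold higher number from compound 2 to compound 3 (0.22 log units; within the scatter), neither beyond the scatter. For the measured compounds named here, no measured step speaks to methoxy groups on that ring. The step of a 1.2-fold lower number from compound 3 to compound 4 (0.07 log units; within the scatter) is therefore expected to stay within the scatter. Compound 4 is estimated at 1200 nM in this assay, with a range from 500 nM to 3000 nM.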

Compound 4, half-maximal inhibitory concentration: 870 nM
Beside the measured number, compound 4's estimate is 1.4-fold (0.14 log units) above it, within the range that was stated.
By their numbers in this assay, from the lowest: compounds 1, 2, 4 and 3 (each within the scatter of the next).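

Putting 3,4-dimethoxyphenyl in place of 2-methylphenyl on the amide-type nitrogen, a change that adds two methoxy groups to the ring, gives in this assay only a 1.6-fold lower number from compound 3 to compound 4 (0.21 log units; within the scatter). The comparisons with the other two compounds are just as small: a 1.0-fold higher number from compound 2 to compound 4 (0.02 log units; within the scatter) and a 1.2-fold higher number from compound 1 to compound 4 (0.07 log units; within the scatter). So methoxy groups on this ring, unlike anything the earlier compounds showed, also produce no step beyond the scatter, and no measurement here offers an explanation for this. Still open, from the compounds shown here alone, is whether a saturated amine such as piperidine on that carbonyl carbon, or a longer chain joining the ester to the shared core, would produce a step beyond the scatter.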